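From compound 3 to compound 4: a chlorophenyl swap

This account rests on a few compounds, and the source may have more. Where it says the series, first, only, none or still open, it means among the compounds named here.

Compound 1 `Cc1cccc(C2CC(c3ccc(Oc4ccccc4)cc3)=NN2c2ccc(S(N)(=O)=O)cc2)c1` gives 35000 nM
Compound 2 `NS(=O)(=O)c1ccc(N2N=C(c3ccc(Oc4ccccc4)cc3)CC2c2ccccc2Cl)cc1` gives 40000 nM
Compound 3 `Cc1ccccc1C1CC(c2ccc(Oc3ccccc3)cc2)=NN1c1ccc(S(N)(=O)=O)cc1` gives 36000 nM

In an ADME assay on MT4 cells (Homo sapiens) for cytotoxicity, read by MTT assay, with a stated time of 96 h (a lower number here means that less compound is tolerated, a higher number that more compound is tolerated), compound 3 stands within the scatter of both other compounds, with a 1.0-fold higher number from compound 1 to compound 3 (0.01 log units; within the scatter) and a 1.1-fold lower number from compound 2 to compound 3 (0.05 log units; within the scatter). Compound 4 `NS(=O)(=O)c1ccc(N2N=C(c3ccc(Oc4ccccc4)cc3)CC2c2ccc(Cl)cc2)cc1` carries 4-chlorophenyl in place of 2-methylphenyl on a saturated ring carbon. The closest evidence is a 1.1-fold higher number from compound 1 to compound 2 (0.06 log units; within the scatter), alongside the two steps above, and all three swap groups at this same carbon or on its ring. For the measured compounds named here, no measured compound carries 4-chlorophenyl. The expected change is none beyond the scatter, an estimated no change at the digits printed from compound 3 to compound 4 (within the scatter). For compound 4 the estimated value in this assay is 36000 nM, with an expected range from 20000 nM to 60000 nM.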

Compound 4, half-maximal cytotoxic concentration: 9000 nM
For compound 4 the middle estimate is 4.0-fold (0.60 log units) above the measured one; measured number outside the range, below it.
By their numbers in this assay, from the lowest: compound 4; then compounds 1, 3 and 2 (each within the scatter of the next).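

In this assay the position proves responsive to the aryl group it carries, with a 4.0-fold lower number from compound 3 to compound 4 (0.60 log units; beyond the scatter), a 3.9-fold lower number from compound 1 to compound 4 (0.59 log units; beyond the scatter) and a 4.4-fold lower number from compound 2 to compound 4 (0.65 log units; beyond the scatter). The last step keeps chlorine and changes only 2-chlorophenyl to 4-chlorophenyl, so among these compounds the shift goes with the 4-chlorophenyl group and not with chlorine as such. Nothing given here accounts for this shift. From the compounds shown here alone, it stays open whether 4-methylphenyl or 4-aminophenyl on this carbon would stand with compound 4 or with compound 1, compound 2 and compound 3.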